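The source may hold more compounds than are shown below. What is called first, only, known or untested is meant among the compounds shown, and "the series" means these compounds.

Working notes on the series. Compound 1 `CN(C(=O)CCCc1ccccc1)c1nc2ccccc2c(=O)s1` is the methylated amide of the shared core; in an assay on mitochondria (strain Sprague-Dawley) for inhibition of Amine oxidase [flavin-containing] B (Rattus norvegicus), read by fluorescence and Amplex Red, with stated times of 30 min and 45 min (a higher number here means a weaker inhibitor, a lower number a stronger inhibitor), compound 1 gives "not determined" (no result reported). Compound 2 `O=C(CCCc1ccccc1)Nc1nc2ccccc2c(=O)s1` gives 186 nM in this assay. Compound 3 `O=C(CCc1ccccc1Br)Nc1nc2ccccc2c(=O)s1` gives 64 nM in this assay. On the numbers available, compound 2 stands highest; its nearest neighbour is compound 3, reached by a 2.9-fold lower number from compound 2 to compound 3 (0.46 log units; beyond the scatter), which places a halogen-bearing aromatic ring on a shorter chain, so the move mixes two changes and is only a partial guide.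

Compound 4 `O=C(CCCc1ccc(Cl)c(Cl)c1)Nc1nc2ccccc2c(=O)s1` differs from compound 2 by 3,4-dichlorophenyl in place of phenyl on a saturated chain carbon, three bonds along the chain from a carbonyl carbon. Within the data shown here, the one bearing step is the halogenation seen in a 2.9-fold lower number from compound 2 to compound 3 (0.46 log units; beyond the scatter). Halogens on the aromatic ring there went with a lower number, so a modest fall in this assay is expected for compound 4, without confidence that it clears the scatter. The expected outcome for compound 4 is 90 nM, with a range from 35 nM to 230 nM, corresponding to an estimated step of a 2.1-fold lower number from compound 2 to compound 4 (0.32 log units; beyond the scatter).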

Compound 4, half-maximal inhibitory concentration: 3300 nM
The estimate for compound 4 lay 37-fold (1.56 log units) below the measured number, and the stated range ends below it.
By their numbers in this assay, from the lowest: compound 3; then compound 2; then compound 4.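

Placing 3,4-dichlorophenyl in place of phenyl on a saturated chain carbon, three bonds along the chain from a carbonyl carbon, gives an 18-fold higher number from compound 2 to compound 4 (1.25 log units; beyond the scatter) in this assay, so halogens on the aromatic ring at this place do not go with a lower number. The earlier 2.9-fold lower number from compound 2 to compound 3 (0.46 log units; beyond the scatter) therefore gives no general halogen trend: it also changes the chain, and compound 4 goes against any such pattern. Nothing in hand accounts for the size of this rise.

As far as these compounds go, it remains open whether the rise needs both chlorines or follows from a single chlorine on the ring, and whether a methoxy group there would behave in the same way. The response of the 3,4-dichlorophenyl ring on a shorter or longer chain is also unresolved.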